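Dichlorophenyl for Difluorophenyl on the Sulfonyl Sulfur

The source may report more compounds than this note shows. Statements on the series, on what has been measured and on what is new or still open speak of the compounds shown alone.

Three compounds have so far been run in an ADME assay on microsomes from liver (Homo sapiens) for metabolic stability, tested at 2.5 uM; a lower number here means slower removal, a higher number faster removal of the compound. Compound 1 `O=S(=O)(c1cc(F)cc(F)c1)c1cnc2c(F)cccc2c1-c1cccc(Cl)c1` gives 0.64 mL/min in this assay, compound 3 `O=S(=O)(c1cc(Cl)cc(Cl)c1)c1cnc2c(F)cccc2c1-c1cccc(Cl)c1` gives 1.2 mL/min, and compound 2 `O=S(=O)(c1cc(F)cc(F)c1)c1cnc2cc(F)ccc2c1-c1ccc(Cl)cc1` gives 0.03 mL/min. Compound 3 carries 3,5-dichlorophenyl in place of 3,5-difluorophenyl on a sulfonyl sulfur relative to compound 1, and that change made a 1.9-fold higher number from compound 1 to compound 3 (0.27 log units; within the scatter). Compound 2 has the lowest number of the three; its nearest neighbour is compound 1, whose value lies beyond the scatter from it, and compound 3 lies further away still. The difference between the cores of compound 1 and compound 2 is not broken down here.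

Compound 4 `O=S(=O)(c1cc(Cl)cc(Cl)c1)c1cnc2cc(F)ccc2c1-c1ccc(Cl)cc1` has not yet been measured in this assay. Among the measured compounds shown here, it carries 3,5-dichlorophenyl in place of 3,5-difluorophenyl on a sulfonyl sulfur, the same change as the one from compound 1 to compound 3, at the same place. Resting on a 1.9-fold higher number from compound 1 to compound 3 (0.27 log units; within the scatter), the expected step is a 2.0-fold higher number from compound 2 to compound 4 (0.30 log units; within the scatter). Compound 4 is therefore estimated at 0.06 mL/min, with a likely range from 0.02 mL/min to 0.18 mL/min, the wider span allowing for the low starting value of compound 2.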

Compound 4, intrinsic clearance in a liver preparation (reported as CLH), per the amount of preparation that the assay uses: 0.13 mL/min
Estimate against measurement, compound 4: 2.2-fold (0.34 log units) below, and the stated range covers the measured number.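

On the core of compound 2, 3,5-dichlorophenyl in place of 3,5-difluorophenyl on a sulfonyl sulfur gave a 4.3-fold higher number from compound 2 to compound 4 (0.64 log units; beyond the scatter) in this assay. This step lies beyond the scatter and the earlier one on the core of compound 1 lies within it, yet the two cannot be told apart: the same change on two cores in this assay, a 1.9-fold higher number (0.27 log units; within the scatter) from compound 1 to compound 3 and a 4.3-fold higher number (0.64 log units; beyond the scatter) from compound 2 to compound 4, 2.3-fold (0.36 log units) apart, within the scatter of two such steps The pairs therefore give no sign that the core alters the effect of this change, but two cores are too few to show that it carries over generally, and the data do not show what sets the size of either step.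

The compounds shown leave open how other groups on the sulfonyl sulfur, such as a 3,5-dimethoxyphenyl, a pyridine or an aliphatic amine, would fare in this assay. They also leave open whether the step would hold on a core carrying a nitrile or a carboxylic acid in place of its fluorine.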